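Permeability notes: from compound 3 to compound 4

The source may report more compounds than this note shows. Statements on the series, on what has been measured and on what is new or still open speak of the compounds shown alone.

Measured compounds:
- compound 1 `CNC(=O)c1cc(Oc2ccc3nc(Nc4cccc(C(C)(C)C)c4)ncc3c2)ccn1`: < 1 10^-6 cm/s in an ADME assay on Caco-2 cells (Homo sapiens) for permeability, in the apical to basolateral direction (a lower number here means that the compound crosses the layer more slowly, a higher number that the compound crosses the layer faster), a limit of the assay and not a number
- compound 2 `CNC(=O)c1cc(Oc2ccc3nc(Nc4ccccc4Br)ncc3c2)ccn1`: < 1 10^-6 cm/s, again only a limit
- compound 3 `CNC(=O)c1cc(Oc2ccc3nc(Nc4cccc(Cl)c4)ncc3c2)ccn1`: < 1 10^-6 cm/s, also only a limit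

All three compounds share one core and differ only in the substituted phenyl on the amine nitrogen. Compound 3 stands where every other value stands: at the limit, with no number to place it against the others. The three measured steps, a step that the two limits leave unreadable from compound 1 to compound 2, a step that the two limits leave unreadable from compound 1 to compound 3 and a step that the two limits leave unreadable from compound 2 to compound 3, cannot be sized because of the limit of < 1 10^-6 cm/s in this assay, at which 3 of the 3 values shown sit.

Compound 4 `CNC(=O)c1cc(Oc2ccc3nc(Nc4cccc(Br)c4)ncc3c2)ccn1` differs from compound 3 by bromo in place of chloro on an aromatic carbon. For the measured compounds named here, no measured step follows this change, and the steps that exist give no readable size; the only evidence is that three substituted phenyl groups, including the chloro one of compound 3, all sit at the limit. The step that the limit leaves unreadable from compound 3 to compound 4 is therefore expected to be none beyond the scatter. Compound 4 is estimated at 0.5 10^-6 cm/s, within 0.1 10^-6 cm/s to 1.5 10^-6 cm/s, most likely reported again as a limit.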

Compound 4, apparent permeability: < 1 10^-6 cm/s
Compound 4: a limit, no number (the forecaster's own chance of this, stated with the estimate: 85%); the middle value does not contradict the limit.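

No step can be sized among compound 1, compound 2, compound 3 and compound 4, since compound 4 also gives only a limit of the assay and not a number: the limit of < 1 10^-6 cm/s in this assay, at which 4 of the 4 values shown sit.

Left open is whether these four compounds differ at all in this assay, and which change to the shared core would give a readable value.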